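The source may report more compounds than this note shows. Statements on the series, on what has been measured and on what is new or still open speak of the compounds shown alone.

Compound 1, `Cc1ccc(C2CC(=O)c3ccc(F)cc3O2)cc1`, was tested in an in vitro assay on BTI-TN-5B1-4 cells for inhibition of Amine oxidase [flavin-containing] A (Homo sapiens), tested at 100 uM (a lower number here means less inhibition, a higher number more inhibition at the concentration tested (going by the name of the read-out)), and compound 1 gave "not active" (no number reported): no number was reported for it. Compound 1 therefore has no single value to stand on, and it is not the only one: compound 2, `Fc1ccc(-c2cc(=S)c3ccc(F)cc3o2)cc1`, was also reported in this assay as "not active" (no number reported), again without a number. The one numbered result in this set belongs to compound 3, `COc1ccc(-c2cc(=O)c3ccc(F)cc3o2)cc1`, which gives 40% in this assay. Among the measured compounds shown here, no step between measured compounds can be counted from these entries, so the values can only be set side by side as they are.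

The compound that follows is compound 4, `Cc1ccc([C@@H]2CC(=O)c3ccc(F)cc3O2)cc1`. Compared with compound 1 the difference is this: the two compounds have the same atoms and bonds; at least one stereo element is drawn with a configuration in one of them and without one in the other: 1 of 1 stereo elements differ; a stereocentre at a saturated ring carbon is drawn without a configuration in compound 1 and S in compound 4. Since the drawing alone changes and nothing enters or leaves, no step beyond the usual scatter is expected in this assay. Compound 4 is therefore expected to give about 10% in this assay, within a range from 0% to 30%, with a real chance that again no number is reported.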

Compound 4, a percentage reported as inhibition, at one concentration (the size of the read-out at that concentration, not a potency): "not active" (no number reported)
Compound 4: no number reported, and the estimate cannot be compared.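

Among the compounds shown here, compound 4, like compound 1, carries no number in this assay, so no step between the two can be read. These compounds leave open whether the configuration at the saturated ring carbon changes inhibition at all, and the only difference on record is: the fact that one of compounds 1 and 4 is drawn with a defined configuration and the other without, at the place where they differ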